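This account rests on a few compounds, and the source may have more. Where it says the series, first, only, none or still open, it means among the compounds named here.

Of the compounds shown here, three sharing one core have been tested in a functional assay on U-251 cells (Homo sapiens) for inhibition, read by sulforhodamine B assay, with a stated time of 48 h, tested at 10 uM; on this read-out lower numbers stand for less inhibition and higher numbers for more inhibition at the one concentration tested (going by the name of the read-out). Compound 1 `c1cn2cc(-c3ccsc3)nc(-c3ccc4ncn(C5CCCCC5)c4c3)c2n1` gives 6.09%. Compound 2 `CC(=O)c1ccc(-c2cn3ccnc3c(-c3ccc4ncn(C5CCCCC5)c4c3)n2)cc1` gives 3.02%. Compound 3 `c1csc(-c2cn3ccnc3c(-c3ccc4ncn(C5CCCCC5)c4c3)n2)c1` gives 3.92%. Compound 3 holds the second highest of these three numbers; its nearest neighbour is compound 2 and its furthest is compound 1, and both gaps lie within the usual scatter of this kind of measurement, so the three compounds cannot be told apart on this read-out.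

Compound 4 `FC(F)(F)c1cccc(-c2cn3ccnc3c(-c3ccc4ncn(C5CCCCC5)c4c3)n2)c1` has not yet been measured. It differs from compound 3 in one place: 3-(trifluoromethyl)phenyl in place of thiophen-2-yl on an aromatic carbon.

Among the compounds with values here, two measured steps bear on this change, since each of them also swaps one aromatic group for another at the same place. The step of a number 3.1 percentage points lower from compound 1 to compound 2 (within the scatter) and the step of a number 0.9 percentage points higher from compound 2 to compound 3 (within the scatter) both stay within the scatter, as does a number 2.2 percentage points lower from compound 1 to compound 3 (within the scatter). Nothing seen so far suggests that exchanging one ring for another at this place moves the read-out beyond the scatter. The step expected here is therefore a number 1.1 percentage points higher from compound 3 to compound 4 (within the scatter), a change that stays within the scatter. Compound 4 is estimated at 5%, with a range from -5% to 15%.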

Compound 4, a percentage reported as inhibition, at one concentration (the size of the read-out at that concentration, not a potency): 5.93%
For compound 4 the middle estimate is 0.9 percentage points below the measured one; the measured number falls inside the stated range.
By their numbers in this assay, from the lowest: compounds 2, 3, 4 and 1 (each within the scatter of the next).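

In this assay, putting 3-(trifluoromethyl)phenyl, with 10 heavy atoms and a six-membered ring of carbon only, in place of thiophen-2-yl, with 5 heavy atoms and a five-membered ring holding sulfur, gives a number 2 percentage points higher from compound 3 to compound 4 (within the scatter), so even this larger exchange on the aromatic carbon next to the ring nitrogen does not separate the two compounds. The other two comparisons agree, with a number 2.9 percentage points higher from compound 2 to compound 4 (within the scatter) and a number 0.2 percentage points lower from compound 1 to compound 4 (within the scatter), which means that all four aromatic groups tried at this place, including the first one carrying fluorine, remain indistinguishable on this read-out. No supporting measurement is available to explain this flat result.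

Every group shown at this place is an aromatic ring, so it remains open whether a group of another kind, such as an amine, a carboxylic acid or a longer carbon chain, would produce a step beyond the scatter. The data also come from a single concentration, which leaves open how these compounds would behave at higher concentrations.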